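A few compounds are considered here, and "the series" means these few. Any claim that something is new, unique, unknown or untested is made for them only; others in the source may bear on it.

Compound 1, `COc1c2cc(c(OC)c1O)Oc1ccc(cc1)[C@@H](O)C[C@@H](O)/C=C/C=C\2`: in a functional assay on SAOS-2 cells (Homo sapiens) for cytotoxicity, read by spectrophotometry and crystal violet staining, with a stated time of 24 h (on this read-out lower numbers stand for an effect already at smaller amounts and higher numbers for an effect only at larger amounts of compound), compound 1 gives > 150000 nM, which is a limit of the assay and not a number.
Compound 2, `Oc1ccc2cc1-c1cc(ccc1O)C[C@H](O)[C@@H](O)[C@@H](O)C[C@@H](O)C2`: compound 2 gives > 150000 nM, again a limit of the assay.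
Compound 3, `O=C1CCc2ccc(O)c(c2)-c2cc(ccc2O)C[C@H](O)C[C@H]1O`: compound 3 gives > 150000 nM, also a limit of the assay.

Compound 3 therefore stands where every measured compound of this set stands: at the limit of > 150000 nM in this assay, at which 3 of the 3 values shown sit. For the measured compounds named here, no two of the measured compounds differ from one another in a single place, so no measured step is available that could show how a change of structure moves the read-out in this assay, and the three limits give no order among compounds 1, 2 and 3.

The compound that follows is compound 4, `O=C1CCc2ccc(O)c(c2)-c2cc(ccc2O)C[C@H](O[C@@H]2O[C@H](CO)[C@H](O)[C@@H](O)[C@H]2O)C[C@H]1O`. It differs from compound 3 by a group of 11 heavy atoms (6 carbon, 5 oxygen; one six-membered non-aromatic ring with 1 hetero atom) in place of a hydrogen atom, on an oxygen on a saturated carbon. With nothing but limits among compounds 1, 2 and 3, there is no measured ground for expecting compound 4 to leave the limit, so the step that the limit leaves unreadable from compound 3 to compound 4 is expected to be none beyond the scatter. Compound 4 is accordingly estimated to sit at 200000 nM, within a range of 50000 nM to 1000000 nM, most likely reported as a limit rather than a number.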

Compound 4, half-maximal effective concentration: > 150000 nM
Compound 4 ended at the assay's limit (the forecaster's own chance of this, stated with the estimate: 85%); the middle value does not contradict the limit.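

In this assay compound 4 gives > 150000 nM, which is a limit of the assay and not a number. Compound 3 also sits at a limit, so no step can be read between compound 3 and compound 4. All the compounds shown share one position: the limit of > 150000 nM in this assay, at which 4 of the 4 values shown sit.

They leave open whether any change of structure can move the read-out off this limit, and in what order the compounds would fall.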